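Notes on the step from compound 3 to compound 4

The source may hold more compounds than are shown below. What is called first, only, known or untested is meant among the compounds shown, and "the series" means these compounds.

Measured in a functional assay on U-251 cells (Homo sapiens); a lower number here means a stronger inhibitor of growth, a higher number a weaker inhibitor of growth
compound 1 `O=S(=O)(/C=C/c1ccc(F)cc1)Cc1ccc(Nc2ncnc3ccccc23)cc1` gives 10 nM
compound 2 `O=S(=O)(/C=C/c1ccc(Cl)cc1)Cc1ccc(Nc2ncnc3ccccc23)cc1` gives 49000 nM
compound 3 `O=S(=O)(/C=C/c1ccc(F)cc1Cl)Cc1ccc(Nc2ncnc3ccccc23)cc1` gives 100000 nM

Compound 3 carries the highest number of the three. The change to compound 4 `O=S(=O)(/C=C/c1ccc(O)cc1)Cc1ccc(Nc2ncnc3ccccc23)cc1` is 4-hydroxyphenyl in place of 2-chloro-4-fluorophenyl on a double-bonded chain carbon bound to a double-bonded chain carbon and reads 4-hydroxyphenyl in place of 2-chloro-4-fluorophenyl on a double-bonded chain carbon bound to a double-bonded chain carbon. The steps of a 10000-fold higher number from compound 1 to compound 3 (4.00 log units; beyond the scatter) and a 4900-fold higher number from compound 1 to compound 2 (3.69 log units; beyond the scatter) are large, while a 2.0-fold higher number from compound 2 to compound 3 (0.31 log units; beyond the scatter) is modest. Going by the values given here, compound 4 has no chloro, like compound 1 alone among those measured, but no measured compound carries hydroxy. In this assay a large move to a lower number is therefore expected, probably short of the full distance to compound 1. The expected move is a 33-fold lower number from compound 3 to compound 4 (1.52 log units; beyond the scatter) with wide uncertainty. Compound 4 is estimated at 3000 nM with an expected range from 30 nM as lower end to 100000 nM as upper end.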

Compound 4, concentration for 50% growth inhibition: 300 nM
Compound 4: the middle estimate sits 10-fold (1.00 log units) above what was measured; low and high end bracket the measured number.
By their numbers in this assay, from the lowest: compound 1; then compound 4; then compound 2; then compound 3.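

In this assay a hydroxy-bearing aryl group at this place, on a double-bonded chain carbon, gives a large gain over both chloro compounds, with a 330-fold lower number from compound 3 to compound 4 (2.52 log units; beyond the scatter) and a 160-fold lower number from compound 2 to compound 4 (2.21 log units; beyond the scatter) as the two steps. Going by these compounds alone, compound 4 is the first compound without chloro to differ clearly from compound 1. With a 30-fold higher number from compound 1 to compound 4 (1.48 log units; beyond the scatter) still beyond the scatter, the absence of chloro alone does not reproduce the number of compound 1.

Going by these compounds, whether methoxy or an amine in place of hydroxy on an aromatic carbon would fall nearer compound 1 or compound 4 remains open. What lies behind these steps also remains open, as no evidence bears on it.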